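From 5-methylpyridin-2-yl to 6-methylpyridazin-3-yl in compound 1

The source may report more compounds than this note shows. Statements on the series, on what has been measured and on what is new or still open speak of the compounds shown alone.

- compound 1 `Cc1ccc([C@@H](C)Oc2cc3onc(CCC(=O)O)c3cc2Cl)nc1`: 3.6 h
- compound 2 `O=C(O)CCn1c(=O)oc2cc(Cl)c(Cl)cc21`: 4.3 h
- compound 3 `O=C(O)CCn1c(=O)oc2cc(OCC3CC3)c(Cl)cc21`: 0.68 h

In an ADME assay on the whole organism (strain Han-Wistar) for metabolic stability, with Rattus norvegicus as the target, read by LC-MS, at a dose of 1 mg/kg by the intravenous route (a higher number here means that the compound lasts longer, a lower number that the compound disappears faster), compound 1 lies within the scatter of compound 2 and beyond the scatter above compound 3. Compound 4 `Cc1ccc([C@@H](C)Oc2cc3onc(CCC(=O)O)c3cc2Cl)nn1` keeps the core of compound 1 and differs in one group: 6-methylpyridazin-3-yl in place of 5-methylpyridin-2-yl on a saturated chain carbon bound to an oxygen on an aromatic ring and a saturated chain carbon. Among the compounds with values here, the only measured step, a 6.3-fold lower number from compound 2 to compound 3 (0.80 log units; beyond the scatter), swaps chloro for cyclopropylmethoxy. It shows that one swap can move the number, but it says nothing about this ring exchange. Within the data shown here, no measured step covers this exchange, so the expected step is a 1.2-fold lower number from compound 1 to compound 4 (0.08 log units; within the scatter), which is none beyond the scatter. For compound 4 the estimated half-life is 3 h, with an expected range of 1.3 h to 6.5 h.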

Compound 4, half-life: 1.5 h
Compound 4: middle estimate off by 2.0-fold (0.30 log units), on the high side; the range from low to high includes it.
By their numbers in this assay, from the lowest: compound 3; then compound 4; then compounds 1 and 2 (each within the scatter of the next).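

In this assay the exchange of the ring gives a 2.4-fold lower number from compound 1 to compound 4 (0.38 log units; beyond the scatter) and so shows that this place, on a saturated chain carbon bound to an oxygen on an aromatic ring and a saturated chain carbon, affects the number. Within the data shown here, the only earlier step concerned a chloro swap elsewhere, whereas here a ring with 2 hetero atoms replaces one with 1 hetero atom. Nothing measured here accounts for the drop. From the compounds shown here alone, it remains open whether the ring's second nitrogen alone sets this result, and how trifluoromethyl in place of the methyl on the 6-methylpyridazin-3-yl ring would compare.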